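Replacing a methyl with an ethyl on the dithiocarbamate sulfur

The source may report more compounds than this note shows. Statements on the series, on what has been measured and on what is new or still open speak of the compounds shown alone.

Measured compounds:
compound 1, `O=C(CSC(=S)N[C@H]1CCOC1=O)Nc1ccc(Br)cc1`: 28300 nM
compound 2, `CSC(=S)N[C@H]1CCOC1=O`: > 128000 nM

Both compounds were tested in a functional assay on SMMC-7721 cells (Homo sapiens) for cytotoxicity, read by MTT assay, with a stated time of 72 h; a lower number here means a stronger inhibitor, a higher number a weaker inhibitor. Compound 1 carries a bromophenyl amide arm and gives 28300 nM. Compound 2 is a much smaller molecule, and for compound 2 the reported value of > 128000 nM is a limit of the assay rather than a number, so compound 2 stands at the limit of > 128000 nM in this assay, at which 1 of the 2 values shown sits, with no measured potency to compare.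

Compound 3, `CCSC(=S)N[C@H]1CCOC1=O`, is not yet measured. It differs from compound 2 by methyl in place of hydrogen on a saturated chain carbon bound to a sulfur.

The change is small and leaves the rest of the molecule untouched. The step of an at least 1.0-fold lower number from compound 2 to compound 3 (0.02 log units; that floor lies within the scatter) is expected to amount to nothing beyond the scatter, so compound 3 is estimated at 120000 nM, within 40000 nM to 400000 nM, and it may well again return only a limit.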

Compound 3, half-maximal inhibitory concentration: > 128000 nM
Compound 3: only a limit was reported (the forecaster's own chance of this, stated with the estimate: 65%); middle value at least 1.0-fold (0.02 log units) away from the limit.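

Compound 2 and compound 3 each returned only a limit, so no step can be read between them, because neither has a number to compare: the limit of > 128000 nM in this assay, at which 2 of the 3 values shown sit.

The compounds shown leave open whether methylsulfanyl and ethylsulfanyl differ at all in this assay.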